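The source may report more compounds than this note shows. Statements on the series, on what has been measured and on what is new or still open speak of the compounds shown alone.

Of the compounds shown here, two have been measured in a functional assay on HepG2 cells (Homo sapiens) for inhibition, read by MTT assay, with a stated time of 72 h; on this read-out lower numbers stand for stronger inhibition and higher numbers for weaker inhibition. Compound 1 `CCc1cccc(-n2cc(COc3cccc(NC(=O)Nc4ccc(Cl)c(C(F)(F)F)c4)c3)nn2)c1` gives 37900 nM. Compound 2 `O=C(Nc1cccc(OCc2cn(-c3ccccc3F)nn2)c1)Nc1ccc(Cl)c(C(F)(F)F)c1` gives 1520 nM. Going by the values given here, the single change between them, 2-fluorophenyl in place of 3-ethylphenyl on an aromatic nitrogen, brought a 25-fold lower number from compound 1 to compound 2 (1.40 log units; beyond the scatter). Among the compounds with values here, compound 2 thus holds the lowest of the two numbers so far, with compound 1 the nearest and separated from it by a gap beyond the scatter.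

Compound 3 `O=C(Nc1cccc(OCc2cn(-c3ccc(Br)cc3)nn2)c1)Nc1ccc(Cl)c(C(F)(F)F)c1` is not yet measured. It differs from compound 2 in one place: 4-bromophenyl in place of 2-fluorophenyl on an aromatic nitrogen. Within the data shown here, the only measured step, from compound 1 to compound 2, concerns the same aryl group on the aromatic nitrogen and was large, showing that this group moves the number strongly, but it compared other substituents and gives no direction for 4-bromophenyl. Nothing else in the set bears on the change. The expected step of a 2.0-fold higher number from compound 2 to compound 3 (0.30 log units; within the scatter) is of uncertain direction, and a wide range is needed. For compound 3 the estimate in this assay is 3000 nM, with a range from 700 nM to 13000 nM.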

Compound 3, half-maximal inhibitory concentration: 2730 nM
For compound 3 the middle estimate is 1.1-fold (0.04 log units) above the measured one; the measured number falls inside the stated range.
By their numbers in this assay, from the lowest: compounds 2 and 3 (each within the scatter of the next); then compound 1.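

In this assay, 4-bromophenyl in place of 2-fluorophenyl on the aromatic nitrogen gives a 1.8-fold higher number from compound 2 to compound 3 (0.25 log units; within the scatter), so these two aryl groups cannot be told apart at this position. Against 3-ethylphenyl, 4-bromophenyl gives a 14-fold lower number from compound 1 to compound 3 (1.14 log units; beyond the scatter), which shows that the large step is not confined to 2-fluorophenyl: two aryl groups that each carry a halogen now stand apart from compound 1, whose 3-ethylphenyl gives the only number beyond the scatter of the others. No independent measurement is available to explain this separation or the closeness of compound 2 and compound 3.

The halogen and its place on the phenyl ring change together between compound 2 and compound 3, leaving their separate contributions unresolved. Also open, on these data alone, is whether the low numbers depend on a halogen at all, or whether a bare phenyl, or a phenyl bearing a methoxy group or an amine, would stay with compound 2 and compound 3 or fall nearer compound 1.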